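A few compounds are considered here, and "the series" means these few. Any claim that something is new, unique, unknown or untested is made for them only; others in the source may bear on it.

In a functional assay on DU-145 cells (Homo sapiens) for cytotoxicity, read by trypan blue exclusion, with a stated time of 96 h (a lower number here means a stronger inhibitor, a higher number a weaker inhibitor), compound 1 (`COc1ccc(NS(=O)(=O)/C=C/c2c(OC)cc(OC)cc2OC)cc1`) gives 200 nM, compound 2 (`COc1cc(OC)c(/C=C/S(=O)(=O)Nc2ccc(OC)c(O)c2)c(OC)c1`) gives 30 nM and compound 3 (`COC(=O)C(C)Nc1cc(NS(=O)(=O)/C=C/c2c(OC)cc(OC)cc2OC)ccc1OC`) gives 100 nM. Compound 3 is level with compound 1 within the scatter, and its number is higher than that of compound 2. Compound 4 (`COC(=O)C(Nc1cc(NS(=O)(=O)/C=C/c2c(OC)cc(OC)cc2OC)ccc1OC)c1ccc(Br)cc1`) carries 4-bromophenyl in place of methyl on a saturated chain carbon bound to a carbonyl carbon and a nitrogen on an aromatic ring. Going by the values given here, no measured step alters this carbon. The closest guide is the step that added the whole side chain, a 2.0-fold lower number from compound 1 to compound 3 (0.30 log units; within the scatter), while a 3.3-fold higher number from compound 2 to compound 3 (0.52 log units; beyond the scatter) shows a modest change where hydroxy is replaced. From the compounds shown here alone, a step beyond the scatter is therefore not expected in this assay, and the direction remains open. The expected step is a 1.2-fold higher number from compound 3 to compound 4 (0.08 log units; within the scatter). Compound 4 is estimated at 120 nM, with an expected range from 30 nM to 500 nM.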

Compound 4, half-maximal inhibitory concentration: 7500 nM
For compound 4 the middle estimate is 63-fold (1.80 log units) below the measured one; the measured number lies above the stated range.
By their numbers in this assay, from the lowest: compound 2; then compounds 3 and 1 (each within the scatter of the next); then compound 4.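

At this saturated chain carbon, bound to a carbonyl carbon and a nitrogen on an aromatic ring, this assay proves highly sensitive: 4-bromophenyl in place of methyl gives a 75-fold higher number from compound 3 to compound 4 (1.88 log units; beyond the scatter) and is the largest step among these compounds. The methyl-bearing side chain itself gave only a 2.0-fold lower number from compound 1 to compound 3 (0.30 log units; within the scatter) on the core of compound 1, so the group at this one carbon matters far more than that earlier step suggested. No available evidence explains this change. Still open, from the compounds shown here alone, is whether the bromine or the aromatic ring accounts for the step. An ethyl or an unsubstituted phenyl at this carbon would help separate the two.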